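This account rests on a few compounds, and the source may have more. Where it says the series, first, only, none or still open, it means among the compounds named here.

Measured so far in a functional assay on MCF7 cells (Homo sapiens) for antiproliferative activity; on this read-out higher numbers stand for weaker inhibition and lower numbers for stronger inhibition:
- Compound 1 `CC(C)=CCc1cc(C(=O)Nc2cc3ccc(OCCCN4CCCCC4)c(C)c3oc2=O)ccc1O`: > 50000 nM (a limit of the assay)
- Compound 2 `CC(C)=CCc1cc(C(=O)Nc2cc3ccc(OCCCN(C)C(C)(C)C)c(C)c3oc2=O)ccc1O`: 1140 nM

For the measured compounds named here, compound 2 holds the only actual number in this assay, since the other result is a limit. For compound 1 the data show (the limit of > 50000 nM in this assay, at which 1 of the 2 values shown sits).

Compound 3 `CC(C)=CCc1cc(C(=O)Nc2cc3ccc(OCCCNCCO)c(C)c3oc2=O)ccc1O` is still to be measured. It differs from compound 2 by (2-hydroxyethyl)amino in place of methyl(tert-butyl)amino on a saturated chain carbon, three bonds along the chain from an oxygen on an aromatic ring.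

Going by the values given here, only one measured step bears on this place: an at least 43-fold lower number from compound 1 to compound 2 (1.64 log units; beyond the scatter). Among the compounds with values here, that single large step shows that exchanging the amino group here can move the read-out far, and it gives methyl(tert-butyl)amino as the only group with a number so far. Leaving that group is therefore expected to raise the number rather than hold it, though one step cannot fix the size. The expected change is a 5.3-fold higher number from compound 2 to compound 3 (0.72 log units; beyond the scatter). Compound 3 is estimated at about 6000 nM, with an expected range from 1200 nM to 40000 nM.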

Compound 3, half-maximal inhibitory concentration: 1560 nM
The estimate for compound 3 lay 3.8-fold (0.59 log units) above the measured number, and the stated range covers the measured number.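

In this assay, the exchange at this place gives a 1.4-fold higher number from compound 2 to compound 3 (0.14 log units; within the scatter), so (2-hydroxyethyl)amino and methyl(tert-butyl)amino cannot be told apart on this read-out, although the two groups differ in their heavy atoms and hydrogen-bond donors. The large step away from piperidin-1-yl now appears with a second group as well, as an at least 32-fold lower number from compound 1 to compound 3 (1.50 log units; beyond the scatter), and so it is not tied to methyl(tert-butyl)amino alone: among these compounds, the two amino groups without a ring give numbers, while the one with a ring does not. The result for compound 1 is a limit of the assay and not a number, so the true size of both steps from it stays unknown: the limit of > 50000 nM in this assay, at which 1 of the 3 values shown sits.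

The compounds shown leave open whether the ring of piperidin-1-yl itself sets compound 1 apart, a question that a pyrrolidine or a morpholine on the same chain carbon would address. They also leave open how an unsubstituted amine or a chain longer than the 3-((2-hydroxyethyl)amino)propyl chain would read in this assay.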